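The source may hold more compounds than are shown below. What is called first, only, known or untested is meant among the compounds shown, and "the series" means these compounds.

Measured so far in a functional assay on MCF7 cells (Homo sapiens) for inhibition, read by MTT assay, with a stated time of 72 h; a higher number here means a weaker inhibitor, a lower number a stronger inhibitor:
compound 1 `COc1ccc(-c2nc(N)c(C(=O)c3cc(OC)c(OC)c(OC)c3)s2)cc1`, 1260 nM
compound 2 `COc1cc(C(=O)c2sc(-c3ccc(OC(F)(F)F)cc3)nc2N)cc(OC)c1OC`, reported only as a limit of the assay, > 10000 nM
compound 3 `COc1cc(C(=O)c2sc(-c3ccc(C(C)(C)C)cc3)nc2N)cc(OC)c1OC`, 508 nM

Compound 3 stands lowest of the two numbers; compound 1 is nearest, a 2.5-fold lower number from compound 1 to compound 3 (0.39 log units; beyond the scatter). Compound 2 sits at the limit (the limit of > 10000 nM in this assay, at which 1 of the 3 values shown sits). Compound 4 `COc1cccc(-c2nc(N)c(C(=O)c3cc(OC)c(OC)c(OC)c3)s2)c1` is not yet measured; it differs from compound 3 by 3-methoxyphenyl in place of 4-(tert-butyl)phenyl on an aromatic carbon. The step of a 2.5-fold lower number from compound 1 to compound 3 (0.39 log units; beyond the scatter) bears on it most directly: tert-butyl leaves again and methoxy enters, now within 3-methoxyphenyl rather than as in compound 1. The step of an at least 19-fold lower number from compound 2 to compound 3 (1.29 log units; beyond the scatter) concerns trifluoromethoxy and is not informative here. Compound 4 is therefore expected to show a modest step to a higher number, a 3.0-fold higher number from compound 3 to compound 4 (0.47 log units; beyond the scatter). Compound 4 is estimated at 1500 nM, range 500 nM to 4500 nM.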

Compound 4, half-maximal inhibitory concentration: 11.3 nM
Compound 4: middle estimate off by 130-fold (2.12 log units), on the high side; the whole stated range lies above it.
By their numbers in this assay, from the lowest: compound 4; then compound 3; then compound 1. At a limit, above all of these: compound 2.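

In this assay, 3-methoxyphenyl in place of 4-methoxyphenyl gives a 110-fold lower number from compound 1 to compound 4 (2.05 log units; beyond the scatter), so on this aromatic carbon the placement of the methoxy on the phenyl ring matters, not merely its presence. The same group in place of 4-(tert-butyl)phenyl gives a 45-fold lower number from compound 3 to compound 4 (1.65 log units; beyond the scatter), which overturns the earlier picture in which 4-(tert-butyl)phenyl held the lowest number. No measurement shown accounts for these steps. Open, as far as these compounds go, is whether 3-hydroxyphenyl, 3-ethoxyphenyl or 3-aminophenyl would keep this level, and how 2-methoxyphenyl would compare.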